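Removing a Methoxy Group: Expected Cytotoxicity of Compound 4

The source may hold more compounds than are shown below. What is called first, only, known or untested is meant among the compounds shown, and "the series" means these compounds.

Compounds measured so far:
- compound 1, `COc1ccc(CNc2nc(SC)nc3ncccc23)cc1`: 58500 nM
- compound 2, `Nc1nc([SeH])nc2ncccc12`: 5890 nM
- compound 3, `CCCCCSc1nc(O)c2ccccc2n1`: 51400 nM

In an ADME assay on BEAS-2B cells (Homo sapiens) for cytotoxicity, read by MTT assay, with a stated time of 72 h (a lower number here means a stronger inhibitor of growth, a higher number a weaker inhibitor of growth), compound 1 gives 58500 nM, the highest of the three numbers. Compound 3 is close to it, and the two values lie within the scatter of each other, so no order can be read between them. Compound 2, with 5890 nM, stands clearly apart on the lower side of compound 1, beyond the scatter.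

Compound 4, `CSc1nc(NCc2ccccc2)c2cccnc2n1`, has not yet been measured in this assay. It differs from compound 1 in one place: hydrogen in place of methoxy on an aromatic carbon, para to a large group. For the measured compounds named here, no pair of measured compounds shows this change, so its effect is unknown from these data.

A change of this small size, on the outer edge of the molecule, is expected to leave the number close to where compound 1 stands, with no step beyond the scatter in either direction. Compound 4 is therefore estimated at 55000 nM, in the range 20000 nM to 150000 nM, an expected step of a 1.1-fold lower number from compound 1 to compound 4 (0.03 log units; within the scatter).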

Compound 4, concentration for 50% growth inhibition: 25900 nM
Estimate against measurement, compound 4: 2.1-fold (0.33 log units) above; low and high end bracket the measured number.
By their numbers in this assay, from the lowest: compound 2; then compounds 4, 3 and 1 (each within the scatter of the next, the first and the last beyond it).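

In this assay, hydrogen in place of methoxy on an aromatic carbon, para to a large group, gives a 2.3-fold lower number from compound 1 to compound 4 (0.35 log units; beyond the scatter). For the compounds shown here, this is the first reading of this position, since the earlier compounds differ from one another in more than one place: taking away a group of only two heavy atoms at the outer edge of the molecule moves the number a modest step past the usual scatter, towards stronger inhibition of growth. Nothing at hand explains why the number moves, so the step stands as an observation without a cause.

As far as these compounds go, what remains open is whether the step follows from losing the oxygen, the carbon or the group as a whole, and a fluorine, a hydroxyl, a methyl or a longer chain such as ethoxy on the same carbon would help to separate these readings. A single pair also leaves open whether the same change would give a step of similar size and direction on a different core, or with other groups elsewhere on the core of compound 1.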